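Ortho substituent swap on the biaryl propanoic acid series

This account rests on a few compounds, and the source may have more. Where it says the series, first, only, none or still open, it means among the compounds named here.

Compound 3 `COc1cc(CCC(=O)O)ccc1-c1ccc2c(C)nn(-c3ccccn3)c2c1` stands lowest of the three measured compounds in a functional assay on cells for agonist activity at Free fatty acid receptor 1 (Mus musculus), read by FLIPR and calcium flux, with a stated time of 5 min (on this read-out lower numbers stand for smaller maximal responses and higher numbers for larger maximal responses), giving 62%. Compound 2 `Cc1nn(-c2ccccn2)c2cc(-c3ccc(CCC(=O)O)cc3)ncc12` gives 86% in this assay, and compound 1 `Cc1nn(-c2ccccn2)c2cc(-c3ccc(CCC(=O)O)cc3)ccc12` gives 95%. Within the data shown here, the only measured step at the position in question is a number 33 percentage points lower from compound 1 to compound 3 (beyond the scatter). Compound 4 `Cc1nn(-c2ccccn2)c2cc(-c3ccc(CCC(=O)O)cc3C#N)ccc12` differs from compound 3 by cyano in place of methoxy on an aromatic carbon. Among the measured compounds shown here, no measured step covers a cyano group at this position, so the expectation rests on compound 1 and compound 3 alone: the estimate for compound 4 is placed between them, with the step of a number 13 percentage points higher from compound 3 to compound 4 (beyond the scatter) expected to be modest and possibly within the scatter. Compound 4 is therefore expected to give about 75%, within the range 55% to 95%.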

Compound 4, largest response reached (reported as efficacy), in percent of the reference or control that the assay uses in the Free fatty acid receptor 1 assay: 47%
The estimate for compound 4 lay 28 percentage points above the measured number, and the stated range ends above it.
By their numbers in the Free fatty acid receptor 1 assay, from the lowest: compound 4; then compound 3; then compounds 2 and 1 (each within the scatter of the next).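

In the Free fatty acid receptor 1 assay, both groups on this aromatic carbon, ortho to a large group, go with a smaller maximal response, and cyano goes further than methoxy: a number 15 percentage points lower from compound 3 to compound 4 (beyond the scatter), and against hydrogen, a number 48 percentage points lower from compound 1 to compound 4 (beyond the scatter). In a physicochemical assay for lipophilicity, using the shake flask method, measured as octanol-water partition, with a stated time of 30 min, at pH 7.4 (a lower number here means a more polar compound, a higher number a more lipophilic compound), compound 3 gives 2.4 and compound 4 gives 2.2, so a number 0.20 log units lower from compound 3 to compound 4 (within the scatter), and this read-out does not separate the pair. Nothing at hand explains the loss of response.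

Open, as far as these compounds go, is whether fluorine or methyl on this carbon keeps the response of compound 1, and whether an amine follows cyano or methoxy.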